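This account rests on a few compounds, and the source may have more. Where it says the series, first, only, none or still open, it means among the compounds named here.

Measured compounds:
compound 1, `COc1ccccc1Oc1c(N)nc(-c2ccc(F)cc2)nc1Cl`, 2990 nM
compound 2, `COc1ccccc1Oc1c(N)nc(-c2ccccc2)nc1OCCO`, 31100 nM

Of the compounds shown here, two have been measured in a functional assay on B16 cells (Mus musculus) for cytotoxicity, read by CCK-8 assay, with a stated time of 24 h; a lower number here means a stronger inhibitor, a higher number a weaker inhibitor. Compound 1 `COc1ccccc1Oc1c(N)nc(-c2ccc(F)cc2)nc1Cl` gives 2990 nM. Compound 2 `COc1ccccc1Oc1c(N)nc(-c2ccccc2)nc1OCCO` gives 31100 nM, the higher of the two numbers; its nearest neighbour is compound 1, whose number is lower by a margin beyond the usual scatter. Compound 1 and compound 2 differ in more than one place, so their two values cannot be read as a single step.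

Compound 3 `COc1ccccc1Oc1c(N)nc(-c2ccc(I)cc2)nc1OCCO` has not yet been measured in this assay. It differs from compound 2 by iodo in place of hydrogen on an aromatic carbon, placed on an aromatic carbon of a six-membered aromatic ring of carbon only, para to a large group; cut one bond further out, the change reads phenyl to 4-iodophenyl. Among the measured compounds shown here, no measured pair shows this change on its own. For the measured compounds named here, the only measured compound carrying a halogen on that ring, compound 1, gives 2990 nM, but it also differs from compound 2 elsewhere. A modest step downward, a 2.6-fold lower number from compound 2 to compound 3 (0.41 log units; beyond the scatter), is expected. Compound 3 is estimated at 12000 nM, within a range from 4000 nM to 35000 nM.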

Compound 3, half-maximal inhibitory concentration: 19600 nM
The estimate for compound 3 lay 1.6-fold (0.21 log units) below the measured number; measured number inside the range.
By their numbers in this assay, from the lowest: compound 1; then compounds 3 and 2 (each within the scatter of the next).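

In this assay, among the compounds shown here, the one comparison that can be read as a single change is a 1.6-fold lower number from compound 2 to compound 3 (0.20 log units; within the scatter), and it lies within the scatter. On this aromatic carbon, para to a large group, iodo in place of hydrogen therefore gives no change that can be told apart from repeat measurement, something the earlier pair could not show. This holds for iodo on the background of compound 2 only, and it says nothing about fluoro, the halogen on that ring in compound 1, which differs from compound 3 in more than one place. Nothing at hand bears on why the number stays where it does.

The compounds shown leave open whether fluoro on its own, on the background of compound 2, would move the number, and so how much of the gap to compound 1 belongs to that ring rather than to the other place where they differ. They also leave open whether a group of another kind on this carbon, such as an amine or a carboxylic acid, would give a step beyond the scatter.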